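The compounds below may be only part of what the source reports. "The series", "measured", "known", "first", "only" and "open" are said of these compounds alone.

Compound 1 `O=C1C(=O)N(CCCNc2ccnc3cc(C(F)(F)F)ccc23)c2cccc(Cl)c21`, compound 2 `O=C1C(=O)N(CCCNc2ccnc3cc(C(F)(F)F)ccc23)c2cccc(Br)c21`, compound 3 `O=C1C(=O)N(CCCNc2ccnc3cc(C(F)(F)F)ccc23)c2cc(Cl)ccc21` and compound 4 `O=C1C(=O)N(CCCNc2ccnc3cc(C(F)(F)F)ccc23)c2cc(Br)ccc21` are built on a shared core that carries a trifluoromethyl group and a single halogen. In a functional assay on MCF7 cells (Homo sapiens) for antiproliferative activity, read by sulforhodamine B assay, with a stated time of 48 h (on this read-out lower numbers stand for stronger inhibition of growth and higher numbers for weaker inhibition of growth), compound 1 gives 18800 nM. In this assay compound 2 gives 34400 nM. The change between them is bromo in place of chloro on an aromatic carbon and the step it made is a 1.8-fold higher number from compound 1 to compound 2 (0.26 log units; within the scatter). In this assay compound 3 gives 14300 nM; the difference between the core of compound 3 and the core of compound 1 is not broken down here. The number for compound 3 stands within the scatter of compound 1 and beyond the scatter of compound 2.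

Compound 4 has not yet been measured. It differs from compound 3 by bromo in place of chloro on an aromatic carbon. For the measured compounds named here, this is the same kind of change as the one between compound 1 and compound 2, not the same: there the new group sits ortho to a fused ring and meta to a fused ring, here it sits meta to a fused ring and para to a fused ring. In this assay, going by the values given here, the expected step is a 1.7-fold higher number from compound 3 to compound 4 (0.24 log units; within the scatter), which rests on the one measured step of this kind, a 1.8-fold higher number from compound 1 to compound 2 (0.26 log units; within the scatter). Compound 4 is accordingly estimated at 25000 nM, with a range from 12000 nM to 55000 nM.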

Compound 4, concentration for 50% growth inhibition: 7980 nM
Beside the measured number, compound 4's estimate is 3.1-fold (0.50 log units) above it; measured number outside the range, below it.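

In this assay the swap of bromo for chloro on compound 3 gives a 1.8-fold lower number from compound 3 to compound 4 (0.25 log units; within the scatter) and, taken alone, this step lies within the scatter, as does the earlier step on the other core. Set side by side, however, the two steps run in opposite directions and the gap between them is beyond the scatter, so in this series the effect of this swap measured on one core cannot simply be carried over to the other: the same change on two cores in this assay, a 1.8-fold higher number (0.26 log units; within the scatter) from compound 1 to compound 2 and a 1.8-fold lower number (0.25 log units; within the scatter) from compound 3 to compound 4, 3.3-fold (0.52 log units) apart, beyond the scatter of two such steps. For the compounds shown here, this rests on only two pairs, and it does not show what sets the two steps apart, nor does either step alone establish that bromo is better or worse than chloro on its own core.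

The compounds shown leave open whether a fluoro, a methyl or a nitrile on the same aromatic carbon would follow the step of one core, of the other, or neither. They also leave open how the halogen swap behaves with a longer chain in the linker, or with a chloro or a methoxy in place of the trifluoromethyl group.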